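Aryl Sulfonyl in Place of Pentyl Sulfonyl

The source may report more compounds than this note shows. Statements on the series, on what has been measured and on what is new or still open speak of the compounds shown alone.

Measured compounds:
- Compound 1, `CC[C@H](C)[C@H](NC(=O)c1cccc(Cn2ccnc2)c1)C(=O)NNS(=O)(=O)c1c(C)cc(C)cc1C`: 10%
- Compound 2, `CC[C@H](C)[C@H](NC(=O)c1cccc(Cn2ccnc2)c1)C(=O)NNC(=O)OC(C)(C)C`: "not determined" (no result reported)
- Compound 3, `CCCCCS(=O)(=O)NNC(=O)[C@@H](NC(=O)c1cccc(Cn2ccnc2)c1)[C@@H](C)CC`: "not determined" (no result reported)

In an assay on HEK293 cells for displacement of a labelled ligand from Type-2 angiotensin II receptor (Homo sapiens), tested at 1 uM (a higher number here means a stronger effect of the compound at the concentration tested, a lower number a weaker effect), compound 1 gives 10%, a weak effect. Compound 2 gives "not determined" (no result reported) there, and compound 3 likewise gives "not determined" (no result reported), so there is nothing to place it against compound 1 or compound 2 directly.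

Compound 4, `CC[C@H](C)[C@H](NC(=O)c1cccc(Cn2ccnc2)c1)C(=O)NNS(=O)(=O)c1ccc(OC)cc1`, differs from compound 3 by 4-methoxyphenyl in place of pentyl on a sulfonyl sulfur. Within the data shown here, no step between measured compounds exists that shows what such a change does in this assay. Among the measured compounds shown here, with compound 1 as the only number, a weak effect is the expectation, and no shift beyond the usual scatter is expected from compound 3 to compound 4. Compound 4 is therefore estimated at 12%, within 0% to 30%.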

Compound 4, a percentage reported as inhibition, at one concentration (the size of the read-out at that concentration, not a potency): 3%
Compound 4: the middle estimate sits 9 percentage points above what was measured; low and high end bracket the measured number.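

Placing 4-methoxyphenyl on the sulfonyl sulfur instead of 2,4,6-trimethylphenyl gives, in this assay, a number 7 percentage points lower from compound 1 to compound 4 (within the scatter), so these two aryl groups cannot be told apart here. Both compounds show only a weak effect, which gives the first sign that this aryl swap on the sulfonyl sulfur does not raise the read-out. Nothing available explains this result.

The step from pentyl to 4-methoxyphenyl cannot be read, since compound 3 has no number. Also open, as far as these compounds go, is whether an amine or a carboxylic acid on the phenyl ring would change the read-out.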